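A smaller ring in place of the nitrophenyl group

This account rests on a few compounds, and the source may have more. Where it says the series, first, only, none or still open, it means among the compounds named here.

Measured so far:
Compound 1 `CC(C)(C)n1ncc(OCc2nnc(-c3cccc(F)c3)o2)c(Cl)c1=O` gives 7100 nM in a functional assay on the whole organism for inhibition, with Mythimna separata as the target, with a stated time of 5 days; a lower number here means that less compound is needed, a higher number that more compound is needed for the effect.
Compound 2 `CC(C)(C)n1ncc(OCc2nnc(-c3ccc([N+](=O)[O-])cc3)o2)c(Cl)c1=O` reaches only the limit of this assay, > 299000 nM.

Compound 2 therefore stands at the weak end of what is shown: its number is not a measurement but a limit, the one at the limit of > 299000 nM in this assay, at which 1 of the 2 values shown sits, so all that is known is that it needs more compound than that. Within the data shown here, the single measured step, an at least 42-fold higher number from compound 1 to compound 2 (1.62 log units; beyond the scatter), was large and beyond the scatter, so the 4-nitrophenyl group goes with a much higher number than the 3-fluorophenyl group. Compound 3 `CC(C)(C)n1ncc(OCc2nnc(-c3ccco3)o2)c(Cl)c1=O` is not yet measured. It differs from compound 2 by furan-2-yl in place of 4-nitrophenyl on an aromatic carbon. Among the measured compounds shown here, no measured step covers furan-2-yl, so only the step away from 4-nitrophenyl is known, and there the change was large. A step back toward the number of compound 1 is therefore expected, roughly an at least 11-fold lower number from compound 2 to compound 3 (1.07 log units; beyond the scatter), though its size is uncertain. For compound 3 the estimate in this assay is 25000 nM, with a likely range from 4000 nM to 200000 nM.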

Compound 3, half-maximal effective concentration: > 299000 nM
Compound 3: no number, only a limit (the forecaster's own chance of this, stated with the estimate: 25%); middle value at least 11-fold (1.07 log units) from the limit.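

In this assay, the smaller furan-2-yl ring does not bring back a measurable number, and compound 3 sits at the limit of the assay, as compound 2 does: the limit of > 299000 nM in this assay, at which 2 of the 3 values shown sit. The step between these two compounds cannot be read, since both ends are limits, so nothing shows which of the two groups is the poorer one. What can be read is an at least 42-fold higher number from compound 1 to compound 3 (1.62 log units; beyond the scatter), so on this aromatic carbon of the five-membered ring the loss is not tied to the 4-nitrophenyl group alone, and among the three groups shown only the 3-fluorophenyl group of compound 1 gives a measured number.

The compounds shown leave open whether the fluorine atom, its place on the ring or the six-membered ring itself goes with that measured number, a question that plain phenyl and 4-fluorophenyl groups would help to separate. They also leave open whether a different five-membered ring such as thiophene-2-yl, or a 3-chlorophenyl group, would give a number in this assay at all.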